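The compounds below may be only part of what the source reports. "The series", "measured", "known", "first", "only" and "open" are said of these compounds alone.

Measured so far:
- compound 1, `O=C(Nc1cccc(N2CCCC2=O)c1)C1CCCN(C(=O)c2cc(C(F)(F)F)cc(C(F)(F)F)c2)C1`: 0%
- compound 2, `O=C(Nc1cccc([N+](=O)[O-])c1)C1CCCN(C(=O)c2cc(C(F)(F)F)cc(C(F)(F)F)c2)C1`: 9%
- compound 3, `COC(=O)c1cccc(NC(=O)C2CCCN(C(=O)c3cc(C(F)(F)F)cc(C(F)(F)F)c3)C2)c1`: 0%

In an ADME assay on PC-3 cells (Homo sapiens) for cytotoxicity, read by WST assay, tested at 100 uM (on this read-out higher numbers stand for more inhibition at the one concentration tested (going by the name of the read-out) and lower numbers for less inhibition), compound 3 stands level with compound 1 at the digits printed, no change at the digits printed from compound 1 to compound 3 (within the scatter), and the second step reads a number 9 percentage points lower from compound 2 to compound 3 (within the scatter); none of the three numbers is separated from another beyond the scatter. All three differ only in the group on one aromatic carbon, and the step of a number 9 percentage points higher from compound 1 to compound 2 (within the scatter) likewise stays within the scatter.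

Compound 4, `O=C(Nc1ccc(Cl)cc1)C1CCCN(C(=O)c2cc(C(F)(F)F)cc(C(F)(F)F)c2)C1`, takes the step from compound 3 with the change (4-chlorophenyl in place of 3-(methoxycarbonyl)phenyl on an amide-type nitrogen). The three measured steps all exchange a substituent on the aromatic ring that sits on the amide-type nitrogen, and each of them stays within the scatter; the change to compound 4 also exchanges that whole ring, including its substituent, for 4-chlorophenyl. For the measured compounds named here, no measured step reaches beyond the scatter, so no step beyond the scatter is expected here either: a number 5 percentage points higher from compound 3 to compound 4 (within the scatter) is the expected step. For compound 4 the estimate in this assay is 5%, with a range from 0% to 20%.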

Compound 4, a percentage reported as inhibition, at one concentration (the size of the read-out at that concentration, not a potency): 14%
For compound 4 the middle estimate is 9 percentage points below the measured one, and the stated range covers the measured number.
By their numbers in this assay, from the lowest: compounds 1, 3, 2 and 4 (each within the scatter of the next, the first and the last beyond it).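

In this assay, for the compounds shown here, the steps of a number 14 percentage points higher from compound 3 to compound 4 (beyond the scatter) and a number 14 percentage points higher from compound 1 to compound 4 (beyond the scatter) are the first beyond the scatter, both modest, while a number 5 percentage points higher from compound 2 to compound 4 (within the scatter) stays within it. The group on the amide-type nitrogen can therefore move this read-out when 4-chlorophenyl enters, but compound 4 is not separated from compound 2, so the 3-nitrophenyl group does not fall clearly on the low side with the other two rings. No evidence at hand bears on why this exchange shifts the number.

On these data alone, whether the chlorine itself or its place on the ring carries the step remains open, since 4-chlorophenyl differs from the other rings in both. Also open, as far as these compounds go, is how this ring would read with an amine, a carboxylic acid or a bromine as its substituent.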